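From 2,6-dichlorophenyl to 2,4-dichlorophenyl on an amide

A few compounds are considered here, and "the series" means these few. Any claim that something is new, unique, unknown or untested is made for them only; others in the source may bear on it.

Measured in an ADME assay on HepG2 cells (Homo sapiens) for cytotoxicity, with a stated time of 3 days; on this read-out lower numbers stand for higher toxicity in this test and higher numbers for lower toxicity in this test:
Compound 1 `O=C(CCSc1nnc(-c2ccncc2)s1)Nc1ccc(Cl)cc1Cl`: > 50000 nM
Compound 2 `CC(CSc1nnc(-c2ccncc2)s1)C(=O)Nc1ccc(Cl)cc1`: > 50000 nM
Compound 3 `CC(CSc1nnc(-c2ccncc2)s1)C(=O)Nc1c(Cl)cccc1Cl`: > 50000 nM

Each of these entries is a limit of the assay and not a number. In this assay compound 3 gives > 50000 nM, which is such a limit. The other two entries look the same, as this summary shows: the limit of > 50000 nM in this assay, at which 3 of the 3 values shown sit. The three compounds therefore cannot be ranked against one another.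

Compound 4 `CC(CSc1nnc(-c2ccncc2)s1)C(=O)Nc1ccc(Cl)cc1Cl` has not yet been measured. It differs from compound 3 in one place: 2,4-dichlorophenyl in place of 2,6-dichlorophenyl on an amide-type nitrogen. In plain terms, 2,4-dichlorophenyl takes the place of 2,6-dichlorophenyl on an amide-type nitrogen, and the two compounds have the same atoms, joined differently.

Among the measured compounds shown here, the one measured step that bears on this change also involves this group: a step that the two limits leave unreadable from compound 2 to compound 3. Its size cannot be read. Compound 1 also carries 2,4-dichlorophenyl. Compound 1 gives > 50000 nM, again a limit.

For the measured compounds named here, nothing measured so far points to a change beyond the scatter, so no such step is expected in this assay, in either direction. The expected step is a number no higher from compound 3 to compound 4 (the limit leaves the size open). For compound 4 the estimate is 50000 nM, with an expected range from 25000 nM to 100000 nM.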

Compound 4, half-maximal cytotoxic concentration: > 50000 nM
Compound 4: a limit, no number (the forecaster's own chance of this, stated with the estimate: 85%); the middle value lies on the limit itself.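

In this assay compound 4 gives > 50000 nM, a limit of the assay and not a number. No step from compound 1, compound 2 or compound 3 to compound 4 can be read, since all four compounds share one entry: the limit of > 50000 nM in this assay, at which 4 of the 4 values shown sit.

The compounds shown leave open how far each lies past that limit, and so whether any of these changes alters toxicity in this test.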